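The source may hold more compounds than are shown below. What is called first, only, known or untested is meant among the compounds shown, and "the series" means these compounds.

Compound 1 `Cc1ccccc1S(=O)(=O)NCc1ccc(CNC(=O)c2ccc(F)cc2)cc1`: 100 nM
Compound 2 `O=C(NCc1ccc(CNS(=O)(=O)c2ccccc2Cl)cc1)c1ccc(F)cc1`: 1000 nM

In an assay on MDA-MB-231 cells for binding affinity to C-X-C chemokine receptor type 4 (Homo sapiens), read by fluorescence and microscopy, with stated times of 10 min and 30 min (a higher number here means that more compound is needed for the effect, a lower number that less compound is needed), compound 2 gives 1000 nM, the highest of the two numbers shown. Its nearest neighbour is compound 1 with 100 nM. For the measured compounds named here, the step between them, a 10-fold higher number from compound 1 to compound 2 (1.00 log units; beyond the scatter), is the only measured change. Compound 3 `O=C(NCc1ccc(CNS(=O)(=O)c2ccc(F)cc2)cc1)c1ccc(F)cc1` has not yet been measured. It differs from compound 2 by 4-fluorophenyl in place of 2-chlorophenyl on a sulfonyl sulfur. Going by the values given here, no measured step covers this exchange: the single step recorded concerns chloro in place of methyl on an aromatic carbon, not a fluorophenyl group, so it bears on compound 3 only loosely. On that thin ground the expectation for compound 3 is a drop of a 2.5-fold lower number from compound 2 to compound 3 (0.40 log units; beyond the scatter), with little confidence in either direction. The estimate for compound 3 in this assay is 400 nM, expected to fall between 100 nM and 2000 nM.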

Compound 3, effective concentration (reported as EC, without a stated level of effect): 1 nM
Compound 3: middle estimate off by 400-fold (2.60 log units), on the high side; measured number below the stated range.
By their numbers in this assay, from the lowest: compound 3; then compound 1; then compound 2.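

In this assay, for the compounds shown here, the group on the sulfonyl sulfur proves to matter far more than the earlier compounds suggested: 4-fluorophenyl in place of 2-chlorophenyl gives a 1000-fold lower number from compound 2 to compound 3 (3.00 log units; beyond the scatter), and 4-fluorophenyl in place of 2-methylphenyl gives a 100-fold lower number from compound 1 to compound 3 (2.00 log units; beyond the scatter). Going by these compounds alone, both steps exceed the only earlier change at this position, a 10-fold higher number from compound 1 to compound 2 (1.00 log units; beyond the scatter), and compound 3 now has the lowest number of the three, with both of its steps beyond the scatter. Nothing available explains this gain in terms of a measured property or mechanism.

Each new step changes the substituent and its place on the ring together, and the compounds shown cannot separate the two. From the compounds shown here alone, it also remains open how an unsubstituted phenyl group, or an amine, would read on the sulfonyl sulfur.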